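This account rests on a few compounds, and the source may have more. Where it says the series, first, only, none or still open, it means among the compounds named here.

Among the measured compounds shown here, in an ADME assay on BHK-21 cells (Mesocricetus auratus) for cytotoxicity, read by MTT assay (on this read-out lower numbers stand for higher toxicity in this test and higher numbers for lower toxicity in this test), only two compounds have been read so far. Compound 1 `C/C(=N\NC(N)=O)c1ccc2[nH]c(-c3ccc(C(F)(F)F)cc3)nc2c1` gives > 100000 nM as a limit and not a number. Compound 2 `C/C(=N\NC(N)=S)c1ccc2[nH]c(-c3ccc(Cl)cc3)nc2c1` gives > 100000 nM as a limit as well. Compound 2 therefore stands only at the limit of > 100000 nM in this assay, at which 2 of the 2 values shown sit, and has no number of its own. Compound 3 `C/C(=N\NC(N)=S)c1ccc2[nH]c(-c3ccc(C(F)(F)F)cc3)nc2c1` differs from compound 2 by trifluoromethyl in place of chloro on an aromatic carbon, para to a large group (trifluoromethyl in place of chloro on an aromatic carbon). Trifluoromethyl is already present in compound 1 and that compound gives > 100000 nM as a limit. No step beyond the scatter is therefore expected in this assay and the estimated step of a number no higher from compound 2 to compound 3 (the limit leaves the size open) is expected to stay within it. The estimated value for compound 3 is 100000 nM with an expected range from 40000 nM to 250000 nM and the assay will probably report only a limit again.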

Compound 3, half-maximal cytotoxic concentration: 5000 nM
Compound 3: the middle estimate sits 20-fold (1.30 log units) above what was measured, outside the stated range (below it).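

In this assay, trifluoromethyl in place of chloro on an aromatic carbon, para to a large group, brings an at least 20-fold lower number from compound 2 to compound 3 (1.30 log units; beyond the scatter), so this position matters when the sulfur-bearing group sits on the amine nitrogen. Trifluoromethyl alone does not settle the read-out, since the sulfur-bearing group in place of the oxygen-bearing one brings an at least 20-fold lower number from compound 1 to compound 3 (1.30 log units; beyond the scatter), and only the compound carrying both trifluoromethyl and the sulfur-bearing group has a number of its own among those shown. Both steps start from a limit, so their full size stays open: the limit of > 100000 nM in this assay, at which 2 of the 3 values shown sit.

The compounds shown leave open whether bromo or methyl on that same aromatic carbon would read like chloro or like trifluoromethyl. They also do not tell how chloro would read together with the oxygen-bearing group.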